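Cytotoxicity: Swapping Phenoxy for a Pyrimidinylaminomethyl Arm

The source may report more compounds than this note shows. Statements on the series, on what has been measured and on what is new or still open speak of the compounds shown alone.

Compound 1 `CC(=O)N1CCC(C(=O)N(CCCN2CCC(CNc3cc(C)ccn3)CC2)c2ccc(C)c(Cl)c2)CC1` gives 17900 nM in an ADME assay (Homo sapiens) for cytotoxicity; a lower number here means that less compound is tolerated, a higher number that more compound is tolerated.
Compound 2 `CC(=O)N1CCC(C(=O)N(CCCN2CCC(Oc3ccccc3)CC2)c2ccc(C)c(Cl)c2)CC1` gives > 56600 nM in this assay, which is a limit of the assay rather than a number.

Compound 2 thus sits at the upper boundary of the numbers shown, as the limit of > 56600 nM in this assay, at which 1 of the 2 values shown sits, records. Compound 3 `CC(=O)N1CCC(C(=O)N(CCCN2CCC(CNc3ncccn3)CC2)c2ccc(C)c(Cl)c2)CC1` carries ((pyrimidin-2-yl)amino)methyl in place of phenoxy on a saturated ring carbon. Within the data shown here, the only measured step that bears on this change is an at least 3.1-fold higher number from compound 1 to compound 2 (0.49 log units; beyond the scatter), which ran in the opposite direction. Reversing it, compound 3 is expected to return into the measurable range, with an expected step of an at least 2.8-fold lower number from compound 2 to compound 3 (0.45 log units; beyond the scatter). Compound 3 is therefore estimated at 20000 nM, within a range of 8000 nM to 60000 nM.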

Compound 3, half-maximal cytotoxic concentration: > 55100 nM
Compound 3 was reported as a limit (the forecaster's own chance of this, stated with the estimate: 25%); middle value at least 2.7-fold (0.44 log units) away from the limit.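

In this assay compound 3 also ends at a limit of the assay: the limit of > 55100 nM in this assay, at which 1 of the 3 values shown sits. Phenoxy is therefore not the only arm on this saturated ring carbon that reaches a limit, and pyrimidin-2-yl in place of 4-methylpyridin-2-yl on the amine nitrogen gives an at least 3.0-fold higher number from compound 1 to compound 3 (0.48 log units; beyond the scatter). Compound 2 and compound 3 both stand as limits, so the step between them cannot be read. On these data alone, how far either compound lies past its limit remains open. So does where an unsubstituted pyridin-2-yl on the amine nitrogen would fall.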